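This account rests on a few compounds, and the source may have more. Where it says the series, first, only, none or still open, it means among the compounds named here.

For the measured compounds named here, in an in vitro functional assay on HEK293-A cells for antagonist activity at metabotropic glutamate receptor 5 (Rattus norvegicus), read by calcium flux (on this read-out lower numbers stand for stronger inhibition and higher numbers for weaker inhibition), compound 3 `COc1ccccc1C(=O)Nc1cccc(NC(=O)c2cccc(F)c2)c1` gives 6480 nM, the only outright number. Compound 1 `COc1ccccc1C(=O)Nc1cccc(NC(=O)c2ccc(Cl)c(Cl)c2)c1` returns only the limit > 30000 nM. Compound 2 `COc1ccccc1C(=O)Nc1cccc(NC(=O)c2cc(Cl)cc(Cl)c2)c1` likewise stops at the limit > 30000 nM. Compound 4 `COc1ccccc1C(=O)Nc1cccc(NC(=O)c2ccc(F)cc2)c1` carries 4-fluorophenyl in place of 3-fluorophenyl on a carbonyl carbon. Going by the values given here, no measured step moves a single fluorine; the steps on the same carbonyl carbon are an at least 4.6-fold lower number from compound 1 to compound 3 (0.66 log units; beyond the scatter) and an at least 4.6-fold lower number from compound 2 to compound 3 (0.66 log units; beyond the scatter), both exchanges of a dichlorophenyl for the 3-fluorophenyl, while a step that the two limits leave unreadable from compound 1 to compound 2 stays unreadable because of the limit of > 30000 nM in this assay, at which 2 of the 3 values shown sit. Their bearing on shifting one fluorine is indirect, so for compound 4 a step of about a 1.4-fold higher number from compound 3 to compound 4 (0.14 log units; within the scatter) toward a somewhat higher number is expected. Compound 4 is therefore estimated at 9000 nM, within 3000 nM to 30000 nM, with a fair chance that only a limit is returned.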

Compound 4, half-maximal inhibitory concentration: > 30000 nM
Compound 4: a limit, no number; the forecaster's own chance of this, stated with the estimate: 30%; middle value at least 3.3-fold (0.52 log units) away from the limit.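

Moving the single fluorine matters in this assay: 4-fluorophenyl in place of 3-fluorophenyl on the carbonyl carbon gives an at least 4.6-fold higher number from compound 3 to compound 4 (0.66 log units; beyond the scatter). The earlier readable steps exchanged a dichlorophenyl for the 3-fluorophenyl, whereas here the atoms stay the same and only their joining changes, leaving compound 3 as the only compound shown with a number. The steps from compound 1 and compound 2 to compound 4 cannot be read: the limit of > 30000 nM in this assay, at which 3 of the 4 values shown sit.

On these data alone, the full size of the step to compound 4 stays open. Also open, as far as these compounds go, is whether a plain phenyl or a trifluoromethylphenyl on the same carbonyl carbon would return a number.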